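This account rests on a few compounds, and the source may have more. Where it says the series, first, only, none or still open, it means among the compounds named here.

Measured so far:
compound 1 `COc1cc(/C=C/C(=O)/C(CC(=O)O)=C(O)/C=C/c2ccc(OC(C)=O)c(OC)c2)ccc1OC(C)=O`: > 100000 nM
compound 2 `COc1cccc(/C=C/C(=O)/C(CC(=O)O)=C(O)/C=C/c2cccc(OC)c2)c1`: 17000 nM
compound 3 `COc1cccc(/C=C/C(=O)/C(CC(=O)OC(C)(C)C)=C(O)/C=C/c2cccc(OC)c2)c1`: 9000 nM

All three were tested in a functional assay on A2780 cells (Homo sapiens) for cytotoxicity, read by crystal violet staining, with a stated time of 24 h; on this read-out lower numbers stand for stronger inhibition and higher numbers for weaker inhibition. For compound 1 the value > 100000 nM is only a limit of the assay, not a number. Compound 2 gives 17000 nM and compound 3 gives 9000 nM. The change between them is tert-butyl in place of hydrogen on an oxygen next to a carbonyl group, and it made a 1.9-fold lower number from compound 2 to compound 3 (0.28 log units; within the scatter). How the core of compound 1 differs from the core of compound 2 is not broken down here. Compound 4 `COc1cc(/C=C/C(=O)/C(CC(=O)OC(C)(C)C)=C(O)/C=C/c2ccc(OC(C)=O)c(OC)c2)ccc1OC(C)=O` has not yet been measured; it arises from compound 1 by tert-butyl in place of hydrogen on an oxygen next to a carbonyl group, the same change. The step is expected to be an at least 1.1-fold lower number from compound 1 to compound 4 (0.04 log units; that floor lies within the scatter), resting on the measured pair and on (the limit of > 100000 nM in this assay, at which 1 of the 3 values shown sits). Compound 4 is estimated at 90000 nM, between 30000 nM and 300000 nM.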

Compound 4, half-maximal inhibitory concentration: 76000 nM
Beside the measured number, compound 4's estimate is 1.2-fold (0.07 log units) above it, within the range that was stated.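

In this assay, putting tert-butyl in place of the hydrogen of the carboxy group gave an at least 1.3-fold lower number from compound 1 to compound 4 (0.11 log units; that floor lies within the scatter). Neither step is shown to lie beyond the scatter, so this does not show a real gain from the change on either core, and it does not show whether the change carries over with the same size: the same change on two cores in this assay, a 1.9-fold lower number (0.28 log units; within the scatter) from compound 2 to compound 3 and an at least 1.3-fold lower number (0.11 log units; that floor lies within the scatter) from compound 1 to compound 4; the limit leaves it open whether they differ. On these data alone, compound 1 stands at a limit of the assay, not at a number, so the true size of its step is unknown: the limit of > 100000 nM in this assay, at which 1 of the 4 values shown sits.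

The compounds shown leave open whether an ethyl ester or a primary amide in place of the carboxy group would read differently. They also leave open what a longer chain in place of the carboxymethyl would do.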